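Halogenated aryl sulfonamides: step from compound 3 to compound 4

A few compounds are considered here, and "the series" means these few. Any claim that something is new, unique, unknown or untested is made for them only; others in the source may bear on it.

Three compounds on a shared core carry different aryl groups on the sulfonamide nitrogen. Compound 1 `COc1ccc(S(=O)(=O)Nc2ccc(C)cc2Br)cc1N1CCNCC1` gives 7.94 nM in an assay on isolated protein for binding affinity to 5-hydroxytryptamine receptor 6 (Homo sapiens); a lower number here means a stronger inhibitor, a higher number a weaker inhibitor; compound 2 `COc1ccc(S(=O)(=O)Nc2ccc(Cl)c(Cl)c2)cc1N1CCNCC1` gives 2.51 nM in this assay; compound 3 `COc1ccc(S(=O)(=O)Nc2cc(Br)cc(Cl)c2Br)cc1N1CCNCC1` gives 3.98 nM in this assay. Compound 3 sits within the scatter of both neighbours: its step from compound 2 is a 1.6-fold higher number from compound 2 to compound 3 (0.20 log units; within the scatter), and its step from compound 1 is a 2.0-fold lower number from compound 1 to compound 3 (0.30 log units; within the scatter). Within the data shown here, the only step that reaches beyond the scatter is a 3.2-fold lower number from compound 1 to compound 2 (0.50 log units; beyond the scatter), a modest one.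

Compound 4 `COc1ccc(S(=O)(=O)Nc2cc(Br)cc(F)c2Cl)cc1N1CCNCC1` is not yet measured. It differs from compound 3 by 5-bromo-2-chloro-3-fluorophenyl in place of 2,5-dibromo-3-chlorophenyl on a sulfonamide nitrogen. All three measured steps are swaps of halogenated or methylated aryl groups at the same place, and two of them stayed inside the scatter while the third was only modest. On that basis the step from compound 3 to compound 4 in this assay is expected to be a 1.0-fold higher number from compound 3 to compound 4 (0.00 log units; within the scatter), with no clear direction. Compound 4 is estimated at 4 nM in this assay, in a range from 1.5 nM to 11 nM.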

Compound 4, inhibition constant: 3.16 nM
Beside the measured number, compound 4's estimate is 1.3-fold (0.10 log units) above it; low and high end bracket the measured number.
By their numbers in this assay, from the lowest: compounds 2, 4, 3 and 1 (each within the scatter of the next, the first and the last beyond it).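

Fluorine appears in the aryl group on the sulfonamide nitrogen only in compound 4, and replacing 2,5-dibromo-3-chlorophenyl with 5-bromo-2-chloro-3-fluorophenyl gives a 1.3-fold lower number from compound 3 to compound 4 (0.10 log units; within the scatter) in this assay, so this change of halogens leaves the number within the scatter. The new group also stays close to 3,4-dichlorophenyl, with a 1.3-fold higher number from compound 2 to compound 4 (0.10 log units; within the scatter), while a 2.5-fold lower number from compound 1 to compound 4 (0.40 log units; beyond the scatter) is a second modest step away from 2-bromo-4-methylphenyl, although compound 3 goes against any clean separation of compound 1 from the polyhalogenated compounds. No supporting data on the compounds bear on these steps.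

All groups shown at this position are phenyl rings carrying halogens or methyl. From the compounds shown here alone, whether the numbers stay this close with an amine, a carboxylic acid or a nitrile on that ring remains open.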